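Hydroxy to dimethylamino on the piperidinyl amide: clearance notes

The source may report more compounds than this note shows. Statements on the series, on what has been measured and on what is new or still open speak of the compounds shown alone.

Compound 1 `C=CC(=O)Nc1cccc(-n2c(-c3nc(-c4cnn(CCN5CCN(C)CC5)c4)cnc3N)nc3ccccc32)c1` carries 2-(4-methylpiperazin-1-yl)ethyl on an aromatic nitrogen; in an ADME assay on liver for metabolic stability, with Liver microsome (Homo sapiens) as the target, using microsomes (on this read-out lower numbers stand for slow clearance and higher numbers for fast clearance), compound 1 gives 60 mL.min-1.g-1. Compound 2 `C=CC(=O)Nc1cccc(-n2c(-c3nc(-c4cnn(C5CCN(CC)CC5)c4)cnc3N)nc3ccccc32)c1` carries 1-ethylpiperidin-4-yl in that place, and in this assay compound 2 gives 197 mL.min-1.g-1, a change of a 3.3-fold higher number from compound 1 to compound 2 (0.52 log units; beyond the scatter). Compound 3 `C=CC(=O)Nc1cccc(-n2c(-c3nc(-c4cnn(C5CCN(C(=O)CO)CC5)c4)cnc3N)nc3ccccc32)c1` carries 1-((hydroxymethyl)carbonyl)piperidin-4-yl. In this assay compound 3 reaches only a limit, > 300 mL.min-1.g-1, so no fixed number stands for it. Its place is the limit of > 300 mL.min-1.g-1 in this assay, at which 1 of the 3 values shown sits. The steps to it read an at least 5.0-fold higher number from compound 1 to compound 3 (0.69 log units; beyond the scatter) and an at least 1.5-fold higher number from compound 2 to compound 3 (0.18 log units; that floor lies within the scatter); the latter has a floor within the scatter, so its true size is open.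

Compound 4 `C=CC(=O)Nc1cccc(-n2c(-c3nc(-c4cnn(C5CCN(C(=O)CN(C)C)CC5)c4)cnc3N)nc3ccccc32)c1` is unmeasured and differs from compound 3 by dimethylamino in place of hydroxy on a saturated chain carbon bound to a carbonyl carbon. Going by the values given here, no measured step alters the group on that chain carbon; the only change on the piperidinyl side chain itself is the ethyl to (hydroxymethyl)carbonyl exchange, and compound 3 already sits at the limit, so a large rise cannot be seen. The expected step is an at least 1.3-fold lower number from compound 3 to compound 4 (0.13 log units; that floor lies within the scatter), toward a lower number or none beyond the scatter, with a fair chance that only a limit is again reported. For compound 4 the estimate in this assay is 220 mL.min-1.g-1, expected between 100 mL.min-1.g-1 and 450 mL.min-1.g-1.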

Compound 4, intrinsic clearance in microsomes in the Liver microsome assay: 66 mL.min-1.g-1
Estimate against measurement, compound 4: 3.3-fold (0.52 log units) above; measured number below the stated range.
By their numbers in the Liver microsome assay, from the lowest: compounds 1 and 4 (each within the scatter of the next); then compound 2. At a limit, above all of these: compound 3.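

Dimethylamino in place of hydroxy on a saturated chain carbon bound to a carbonyl carbon is the first measured change at this place. In the Liver microsome assay compound 4 gives 66 mL.min-1.g-1. The step in the Liver microsome assay reads an at least 4.5-fold lower number from compound 3 to compound 4 (0.65 log units; beyond the scatter), a size that is only a floor. In the Liver microsome assay compound 3 holds only a limit, > 300 mL.min-1.g-1: the limit of > 300 mL.min-1.g-1 in the Liver microsome assay, at which 1 of the 4 values shown sits. The ((dimethylamino)methyl)carbonyl group in place of ethyl on an amine nitrogen in a ring gives a 3.0-fold lower number from compound 2 to compound 4 (0.47 log units; beyond the scatter), so the high number of compound 3 does not hold for both amides on the piperidinyl side chain, and the step of a 1.1-fold higher number from compound 1 to compound 4 (0.04 log units; within the scatter) sets the amide of compound 4 level with the 2-(4-methylpiperazin-1-yl)ethyl side chain of compound 1.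

In a physicochemical assay for solubility, at pH 7.4 (on this read-out lower numbers stand for lower solubility and higher numbers for higher solubility), compound 3 holds only a limit, < 10000 nM. In the physicochemical assay compound 4 gives 18000 nM. From the compounds shown here alone, the reading in the physicochemical assay is an at least 1.8-fold higher number from compound 3 to compound 4 (0.25 log units; that floor lies within the scatter), so the size of that step remains open. Also open, going by these compounds, is whether a primary amine, a pyrrolidine or a carboxylic acid on the same chain carbon would keep the lower number in the Liver microsome assay, and how much of the step belongs to the amine nitrogen rather than to the two methyl groups.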